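Triazole aryl swap in the spiro series: compound 3 to 4

The compounds below may be only part of what the source reports. "The series", "measured", "known", "first", "only" and "open" are said of these compounds alone.

Compound 1 `COc1ccccc1-n1nncc1CN1C(=O)C2(C(C#N)=C(N)Oc3c2c2nc4ccccc4nc2c2ccccc32)c2ccccc21` gives a limit in a functional assay on HCT-116 cells (Homo sapiens) for antiproliferative activity, read by MTT assay, with a stated time of 48 h; on this read-out lower numbers stand for stronger inhibition and higher numbers for weaker inhibition: > 50000 nM.
Compound 2 `N#CC1=C(N)Oc2c(c3nc4ccccc4nc3c3ccccc23)C12C(=O)N(Cc1cnnn1-c1cc(Cl)ccc1Cl)c1ccccc12` gives a limit in this assay: > 50000 nM.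
Compound 3 `N#CC1=C(N)Oc2c(N)cc3nc4ccccc4nc3c2C12C(=O)N(Cc1cnnn1-c1ccccc1Cl)c1ccccc12` gives a limit in this assay: > 50000 nM.

In this assay compound 3 stands at the limit, as do both other values; (the limit of > 50000 nM in this assay, at which 3 of the 3 values shown sit). Compound 4 `N#CC1=C(N)Oc2c(N)cc3nc4ccccc4nc3c2C12C(=O)N(Cc1cnnn1-c1c(F)cccc1F)c1ccccc12` is not yet measured. The change is 2,6-difluorophenyl in place of 2-chlorophenyl on an aromatic nitrogen. Among the measured compounds shown here, the one measured step at the same aromatic nitrogen is a step that the two limits leave unreadable from compound 1 to compound 2; both of its ends are limits, so its size cannot be read. No readable step bears on the change, and nothing points to a move beyond the scatter in either direction. Compound 4 is expected to stay at the limit, so a step that the limit leaves unreadable from compound 3 to compound 4 is the expected step. The estimate for compound 4 is 70000 nM, within 30000 nM to 300000 nM.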

Compound 4, half-maximal inhibitory concentration: > 50000 nM
Compound 4 gave a limit, no number; the forecaster's own chance of this, stated with the estimate: 85%; the middle value lies beyond the limit too.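

Compound 3 and compound 4 both sit at a limit in this assay, so no step between them can be read: the limit of > 50000 nM in this assay, at which 4 of the 4 values shown sit.

The compounds shown leave open whether any group on this aromatic nitrogen brings a measurable number.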